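This account rests on a few compounds, and the source may have more. Where it says the series, first, only, none or still open, it means among the compounds named here.

Working notes on the series. Of the compounds shown here, two have been measured in an assay on isolated protein for antagonist activity at advanced glycosylation end product-specific receptor (Homo sapiens), read by ELISA, with a stated time of 60 min, tested at 10 uM; on this read-out higher numbers stand for more inhibition at the one concentration tested (going by the name of the read-out) and lower numbers for less inhibition. Compound 1 `CCCCc1nc(-c2ccc(Oc3ccc(Cl)cc3)cc2)sc1-c1ccc(OCCCN(CC)CC)cc1` gives 57.1% in this assay. Compound 2 `CCCCc1nc(-c2ccc(OCCCN(CC)CC)cc2)sc1-c1ccc(Oc2ccc(Cl)cc2)cc1` gives 49.6% in this assay. Among the measured compounds shown here, compound 2 stands lowest of the two numbers, but its only neighbour, compound 1, lies within the usual scatter of it, so no order between the two can be read from these values.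

Compound 3 `CCCCc1nc(-c2ccc(OCC3CCCN(CC)C3)cc2)sc1-c1ccc(Oc2ccc(Cl)cc2)cc1` is not yet measured. It differs from compound 2 by 1-ethylpiperidin-3-yl in place of 2-(diethylamino)ethyl on a saturated chain carbon bound to an oxygen on an aromatic ring. For the measured compounds named here, no step between measured compounds of this kind exists, so nothing measured tells how the change should read; the amine chain is closed into a ring carrying one more heavy atom, and the single hydrogen-bond acceptor is kept. The expected step in this assay is small, in no fixed direction, and likely within the scatter. Compound 3 is expected to give about 47% in this assay, with a range from 22% to 70%. The step of a number 2.6 percentage points lower from compound 2 to compound 3 (within the scatter) this estimate implies is expected to stay within the scatter.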

Compound 3, a percentage reported as inhibition, at one concentration (the size of the read-out at that concentration, not a potency): 47.7%
Compound 3: the middle estimate sits 0.7 percentage points below what was measured, and the stated range covers the measured number.
By their numbers in this assay, from the lowest: compounds 3, 2 and 1 (each within the scatter of the next).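

In this assay, among the compounds shown here, the change to 1-ethylpiperidin-3-yl in place of 2-(diethylamino)ethyl on a saturated chain carbon bound to an oxygen on an aromatic ring reads as a number 1.9 percentage points lower from compound 2 to compound 3 (within the scatter) and is the only step available at this position. At this one concentration, closing the amine chain into a six-membered ring, with one more heavy atom and the single hydrogen-bond acceptor kept, leaves the read-out within the scatter, so the open chain is not needed to retain this level of inhibition. Nothing measured explains why the two forms read alike.

As far as these compounds go, what a morpholine ring or a carboxylic acid at the end of this chain would give remains open. Also open, from the compounds shown here alone, is whether the same ring closure reads alike on the arrangement of compound 1 .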